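Removing a Methyl from an Aromatic Oxygen: Two Cases

The source may hold more compounds than are shown below. What is called first, only, known or untested is meant among the compounds shown, and "the series" means these compounds.

Measured compounds:
compound 1, `COc1ccc2cc(-c3ccc(OC(F)(F)F)cc3)c(=O)oc2c1CCC(C)C`, 310 nM
compound 2, `CC(C)CCc1c(O)ccc2cc(-c3ccc(OC(F)(F)F)cc3)c(=O)oc12`, 7420 nM
compound 3, `COc1ccc2c(Oc3ccc4ccc(=O)oc4c3CCC(C)C)cc(=O)oc2c1`, a limit only, > 50000 nM

The three were tested in a functional assay on MDA-MB-231 cells (Homo sapiens) for inhibition, read by MTT assay; a lower number here means a stronger inhibitor, a higher number a weaker inhibitor. Compound 1 gives 310 nM and compound 2 gives 7420 nM. The change between them is hydrogen in place of methyl on an oxygen on an aromatic ring; it produced a 24-fold higher number from compound 1 to compound 2 (1.38 log units; beyond the scatter). Compound 3 gives only a limit of this assay, > 50000 nM, and so stands at the limit of > 50000 nM in this assay, at which 1 of the 3 values shown sits. The difference between the core of compound 1 and the core of compound 3 is not broken down here.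

Compound 4, `CC(C)CCc1c(Oc2cc(=O)oc3cc(O)ccc23)ccc2ccc(=O)oc12`, has not yet been measured in this assay. It differs from compound 3 by hydrogen in place of methyl on an oxygen on an aromatic ring, which is the same change as that between compound 1 and compound 2, at the same kind of place.

Compound 4 is expected to remain at the limit, with an expected step that the limit leaves unreadable from compound 3 to compound 4. That expectation rests on compound 3 standing at the limit of > 50000 nM in this assay, at which 1 of the 3 values shown sits, and on the weakening seen in a 24-fold higher number from compound 1 to compound 2 (1.38 log units; beyond the scatter). Compound 4 is estimated at 150000 nM, between 40000 nM and 600000 nM.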

Compound 4, half-maximal inhibitory concentration: > 50000 nM
Compound 4: a limit, no number (the forecaster's own chance of this, stated with the estimate: 90%); the middle value is on the limit's open side.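

In this assay compound 4 gives > 50000 nM, which is a limit and not a number. Compound 3 likewise gives a limit, > 50000 nM, so no step can be read between compound 3 and compound 4. The compounds shown leave open whether methoxy to hydroxy changes the value on the core of compound 3 as it does on the core of compound 1.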